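From 3-methoxyphenyl to furan-2-yl: what to expect

This account rests on a few compounds, and the source may have more. Where it says the series, first, only, none or still open, it means among the compounds named here.

compound 1 `CN(C)c1ccc(C=C2C(=O)N(c3ccc(Cl)cc3)N(c3ccc(Cl)cc3)C2=O)cc1` gives > 128000 nM (a limit, not a number)
compound 2 `O=C1C(=Cc2ccc(Br)cc2)C(=O)N(c2ccc(Cl)cc2)N1c1ccc(Cl)cc1` gives 16600 nM
compound 3 `COc1cccc(C=C2C(=O)N(c3ccc(Cl)cc3)N(c3ccc(Cl)cc3)C2=O)c1` gives 30200 nM

All three compounds were tested in a functional assay on SMMC-7721 cells (Homo sapiens) for cytotoxicity, read by MTT assay, with a stated time of 72 h (a lower number here means a stronger inhibitor, a higher number a weaker inhibitor), and share one core. The value for compound 1 is > 128000 nM and is a limit of the assay. Within the data shown here, the only gap between two true numbers is a 1.8-fold higher number from compound 2 to compound 3 (0.26 log units; within the scatter) and this leaves compound 3 with no clear rank against its one measured neighbour.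

The next compound is compound 4 `O=C1C(=Cc2ccco2)C(=O)N(c2ccc(Cl)cc2)N1c1ccc(Cl)cc1` and it has not been measured. It differs from compound 3 by furan-2-yl in place of 3-methoxyphenyl on a double-bonded chain carbon bound to a double-bonded ring carbon in a swap of furan-2-yl in place of 3-methoxyphenyl on a double-bonded chain carbon bound to a double-bonded ring carbon.

Among the measured compounds shown here, three measured steps bear on this swap. Two of them start from the limit, an at least 7.7-fold lower number from compound 1 to compound 2 (0.88 log units; beyond the scatter) and an at least 4.2-fold lower number from compound 1 to compound 3 (0.62 log units; beyond the scatter), and both lie beyond the scatter. The third, a 1.8-fold higher number from compound 2 to compound 3 (0.26 log units; within the scatter), is the closer guide, since it exchanges one group for another at the same place without reaching a limit. For the measured compounds named here, no measured compound carries a five-membered ring there, and the guide is loose.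

In this assay no step beyond the scatter is expected. The expected step is a 1.1-fold lower number from compound 3 to compound 4 (0.05 log units; within the scatter) and it remains only an estimate. The estimate for compound 4 is 27000 nM with 9000 nM to 90000 nM as the expected range.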

Compound 4, half-maximal inhibitory concentration: 19500 nM
Compound 4: middle estimate off by 1.4-fold (0.14 log units), on the high side; low and high end bracket the measured number.
By their numbers in this assay, from the lowest: compounds 2, 4 and 3 (each within the scatter of the next). At a limit, above all of these: compound 1.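

In this assay, furan-2-yl brings a five-membered aromatic ring with 1 hetero atom to this place, and its 5 heavy atoms replace the 8 of 3-methoxyphenyl, yet the change gives a 1.5-fold lower number from compound 3 to compound 4 (0.19 log units; within the scatter). Against the other six-membered aromatic ring the result is similar, with a 1.2-fold higher number from compound 2 to compound 4 (0.07 log units; within the scatter), so among compounds 2, 3 and 4 neither the ring size nor the swap of these groups produces a clear difference at this place. Compound 4 also joins compounds 2 and 3 in parting clearly from the 4-(dimethylamino)phenyl group, with an at least 6.5-fold lower number from compound 1 to compound 4 (0.81 log units; beyond the scatter), but the true size of that step stays unknown, as compound 1 gives a limit and not a number: the limit of > 128000 nM in this assay, at which 1 of the 4 values shown sits.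

The compounds shown leave open whether other five- or six-membered rings at this place, such as thiophene or pyridine, would also stay within the scatter of compounds 2, 3 and 4. They also leave open whether a primary amine or a carboxylic acid on the phenyl ring would part from these compounds as compound 1 does, or whether the dimethylamino group stands alone in doing so.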